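The source may report more compounds than this note shows. Statements on the series, on what has been measured and on what is new or still open speak of the compounds shown alone.

Measured so far:
compound 1 `CC1=CC[C@H](C(C)(C)NC(=S)N/N=C/c2ccc(O)cc2)CC1` — in a functional assay on U-251 cells (Homo sapiens) for inhibition, read by sulforhodamine B assay, with a stated time of 48 h (on this read-out lower numbers stand for stronger inhibition of growth and higher numbers for weaker inhibition of growth), compound 1 sits at > 100000 nM, which is a limit of the assay and not a number.
compound 2 `CC1=CC[C@H](C(C)(C)NC(=S)N/N=C/c2ccc[nH]2)CC1` — in this assay compound 2 gives 80 nM.

Among the compounds with values here, compound 2 thus holds the only real number in this assay; the other entry is a limit (the limit of > 100000 nM in this assay, at which 1 of the 2 values shown sits). Within the data shown here, the single measured step, an at least 1200-fold lower number from compound 1 to compound 2 (3.09 log units; beyond the scatter), shows that the group on the carbon with a double bond to nitrogen moves this read-out very strongly, though from a limit, so its exact size is open.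

Compound 3 `CC1=CC[C@H](C(C)(C)NC(=S)N/N=C/c2cccs2)CC1` differs from compound 2 by thiophen-2-yl in place of 1H-pyrrol-2-yl on a carbon with a double bond to nitrogen. The ring stays five-membered and aromatic with one hetero atom, but the one hydrogen-bond donor leaves and one hydrogen-bond acceptor enters. The measured step bears on this only in showing how sensitive that position is; it gives no direction for a swap between two five-membered rings. Some loss is therefore expected rather than a gain. The expected step is a 6.3-fold higher number from compound 2 to compound 3 (0.80 log units; beyond the scatter). For compound 3 in this assay the estimate is 500 nM, with a range from 50 nM to 10000 nM.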

Compound 3, concentration for 50% growth inhibition: 13500 nM
Beside the measured number, compound 3's estimate is 27-fold (1.43 log units) below it; measured number above the stated range.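

In this assay, the swap at the carbon with a double bond to nitrogen gives a 170-fold higher number from compound 2 to compound 3 (2.23 log units; beyond the scatter), so two five-membered aromatic rings with 1 hetero atom and the same heavy-atom count are far from interchangeable here, and this single step cannot separate the departing hydrogen-bond donor from the entering hydrogen-bond acceptor or the sulfur atom. The further step, an at least 7.4-fold lower number from compound 1 to compound 3 (0.86 log units; beyond the scatter), places thiophen-2-yl ahead of 4-hydroxyphenyl on this read-out, while 1H-pyrrol-2-yl stands well ahead of both, so the three groups at this position fall into a clear order. Compound 1 sits at a limit of the assay and not at a number, which leaves the size of its steps open: the limit of > 100000 nM in this assay, at which 1 of the 3 values shown sits.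

Still open, from the compounds shown here alone, is whether the ring nitrogen-hydrogen of 1H-pyrrol-2-yl carries the effect, a question that 1-methyl-1H-pyrrol-2-yl would address directly, and furan-2-yl or imidazol-2-yl would test the role of the ring hetero atom. The compounds shown also say nothing on whether the order of these groups holds when the shared core changes, or in any other cell line.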